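This account rests on a few compounds, and the source may have more. Where it says the series, first, only, none or still open, it means among the compounds named here.

Compound 1 (`Cc1cccc(N(C)S(=O)(=O)C2CC3OC2C(c2ccc(NC(=O)CCCCCCC(=O)O)cc2)=C3c2ccc(O)cc2)c1`), compound 2 (`COc1cccc(N(C)S(=O)(=O)C2CC3OC2C(c2ccc(NC(=O)CCCCCCC(=O)O)cc2)=C3c2ccc(O)cc2)c1`) and compound 3 (`CCN(c1ccc(O)cc1)S(=O)(=O)C1CC2OC1C(c1ccc(NC(=O)CCCCCCC(=O)O)cc1)=C2c1ccc(O)cc1`) share one core and differ in the group on the sulfonyl sulfur. In an ADME assay on Vero cells (Chlorocebus sabaeus) for antiproliferative activity, read by MTT assay, with a stated time of 72 h (on this read-out lower numbers stand for stronger inhibition and higher numbers for weaker inhibition), compound 1 gives > 100000 nM as its result, a limit of the assay and not a number. In this assay compound 2 gives > 100000 nM as its result, again a limit. In this assay compound 3 gives > 100000 nM as its result, also only a limit. So compound 3 stands with the others, and the limit of > 100000 nM in this assay, at which 3 of the 3 values shown sit, is all the series shows so far.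

Compound 4 (`CCN(c1ccccc1Br)S(=O)(=O)C1CC2OC1C(c1ccc(NC(=O)CCCCCCC(=O)O)cc1)=C2c1ccc(O)cc1`) carries 2-bromophenyl in place of 4-hydroxyphenyl on a sulfonamide nitrogen. The measured steps that touch this part of the molecule are a step that the two limits leave unreadable from compound 1 to compound 3 and a step that the two limits leave unreadable from compound 2 to compound 3 and also a step that the two limits leave unreadable from compound 1 to compound 2 in the same group. None of them offers a size to carry over, so no step beyond the usual scatter is expected in this assay in either direction. The estimated change is a number no higher from compound 3 to compound 4 (the limit leaves the size open) and no more. Compound 4 is estimated at 100000 nM with an expected range from 40000 nM to 200000 nM and may well turn out to be only a limit.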

Compound 4, half-maximal inhibitory concentration: > 100000 nM
Compound 4 was reported as a limit; the forecaster's own chance of this, stated with the estimate: 85%; the middle value sits exactly at the limit.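

In this assay compound 4 gives > 100000 nM, again a limit and not a number. No step to compound 4 from compound 1, compound 2 or compound 3 can be read: the limit of > 100000 nM in this assay, at which 4 of the 4 values shown sit.

The compounds shown leave open whether changing the group on the sulfonyl sulfur alters this result at all.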